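The source may report more compounds than this note shows. Statements on the series, on what has been measured and on what is new or still open speak of the compounds shown alone.

Three compounds share one core. Compound 1 `Cc1ccc(OC[C@@H]2CCN2)cn1` gives in an assay on brain for binding affinity to Neuronal acetylcholine receptor; alpha4/beta2 (Rattus norvegicus), read by radioligand binding (a lower number here means a stronger inhibitor, a higher number a weaker inhibitor), 0.057 nM, compound 2 `CCc1ccc(OC[C@@H]2CCN2)cn1` gives 19 nM, and compound 3 `N#Cc1ccc(OC[C@@H]2CCN2)cn1` gives 1.9 nM. Compound 3 thus holds the second highest of the three numbers, separated from its neighbours by a 10-fold lower number from compound 2 to compound 3 (1.00 log units; beyond the scatter) and by a 33-fold higher number from compound 1 to compound 3 (1.52 log units; beyond the scatter). Compound 4 `COc1ccc(OC[C@@H]2CCN2)cn1` differs from compound 3 by methoxy in place of cyano on an aromatic carbon. Among the compounds with values here, the steps that bear on this exchange are the same two, a 33-fold higher number from compound 1 to compound 3 (1.52 log units; beyond the scatter) and a 10-fold lower number from compound 2 to compound 3 (1.00 log units; beyond the scatter), both large, showing that changes at this aromatic carbon move this assay strongly in either direction. A step of modest size, with no firm direction, is therefore expected. Compound 4 is expected to give about 1.5 nM, between 0.2 nM and 12 nM. For compound 4 this means an expected step of a 1.3-fold lower number from compound 3 to compound 4 (0.10 log units; within the scatter).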

Compound 4, inhibition constant: 1.3 nM
Beside the measured number, compound 4's estimate is 1.2-fold (0.06 log units) above it; the range from low to high includes it.
By their numbers in this assay, from the lowest: compound 1; then compounds 4 and 3 (each within the scatter of the next); then compound 2.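

In this assay, methoxy and cyano cannot be told apart on this aromatic carbon next to the ring nitrogen, with a 1.5-fold lower number from compound 3 to compound 4 (0.16 log units; within the scatter) lying within the scatter. The gap to ethyl therefore holds for a second group, with a 15-fold lower number from compound 2 to compound 4 (1.16 log units; beyond the scatter) as its size. Methoxy does not close the gap to methyl either, as a 23-fold higher number from compound 1 to compound 4 (1.36 log units; beyond the scatter) shows. On these data alone, whether chlorine, an amine or a propyl chain here would stay level with compound 4 or move towards compound 1 or compound 2 remains open. Nothing given here explains these steps.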